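The source may hold more compounds than are shown below. What is called first, only, known or untested is meant among the compounds shown, and "the series" means these compounds.

Measured compounds in a functional assay on PC-3 cells (Homo sapiens) for inhibition, read by sulforhodamine B assay, with a stated time of 48 h, tested at 50 uM; a lower number here means less inhibition of growth, a higher number more inhibition of growth at the concentration tested:
compound 1 `COc1ccc(/C=C/C(=O)/C=C/c2ccc(OCc3cn(CCCCCOc4cc(=O)oc5ccccc45)nn3)c(OC)c2)cc1` gives "not active" (no number reported)
compound 2 `COc1ccc(/C=C/C(=O)/C=C/c2ccc(OCc3cn(CCOc4cc(=O)oc5ccccc45)nn3)c(OC)c2)cc1OC` gives 19%
compound 3 `COc1cccc(/C=C/C(=O)/C=C/c2ccc(OCc3cn(CCCCOc4cc(=O)oc5ccccc45)nn3)c(OC)c2)c1` gives "not active" (no number reported)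

Compound 3 stands without a single number in this assay: it is recorded as not active, and compound 1 stands the same way. Only compound 2 has a figure, and that figure is small. Compound 4 `COc1ccc(/C=C/C(=O)/C=C/c2ccc(OCc3cn(CCCCOc4cc(=O)oc5ccccc45)nn3)c(OC)c2)cc1` is the next compound to be measured in this assay. It differs from compound 3 in one place: 4-methoxyphenyl in place of 3-methoxyphenyl on a double-bonded chain carbon bound to a double-bonded chain carbon. Going by the values given here, the two compounds have the same atoms, joined differently, and no step between measured compounds is known for this change. Since compound 3 sits among the inactive entries and compound 1, which also carries a 4-methoxyphenyl group on the same chain, is recorded as "not active" (no number reported), the expectation is for no movement beyond the scatter, with the result for compound 4 most likely remaining at the low end of the scale. Compound 4 is estimated at 10%, within a range from 0% to 25%.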

Compound 4, percent growth inhibition at one concentration: "not active" (no number reported)
For compound 4 the study gives words and no number, and the estimate cannot be compared.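

In this assay compound 3 gives "not active" (no number reported) and compound 4 gives "not active" (no number reported) so no step can be read between them. The compounds shown leave open whether 4-methoxyphenyl in place of 3-methoxyphenyl alters growth inhibition at all. No other information available bears on this result.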